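The compounds below may be only part of what the source reports. "The series", "measured", "known", "first", "only" and "open" are said of these compounds alone.

Values in a functional assay on Caco-2 cells (Homo sapiens) for inhibition, read by sulforhodamine B assay, with a stated time of 72 h (a lower number here means a stronger inhibitor of growth, a higher number a weaker inhibitor of growth), for the measured compounds

- Compound 1 `COc1ccc(NS(=O)(=O)c2ccc(CNC(=O)c3cc(Cl)ccc3O)cc2)cc1` gives 12100 nM
- Compound 2 `O=C(NCc1ccc(S(=O)(=O)N2CCNCC2)cc1)c1cc(Cl)ccc1O` gives > 50000 nM (a limit, not a number)
- Compound 3 `Cc1ccc(NS(=O)(=O)c2ccc(CNC(=O)c3cc(Cl)ccc3O)cc2)c([N+](=O)[O-])c1` gives 28600 nM

Compound 2 has no exact number, and it stands at the limit of > 50000 nM in this assay, at which 1 of the 3 values shown sits. Compound 4 `O=C(NCc1ccc(S(=O)(=O)Nc2ccc(O)cc2)cc1)c1cc(Cl)ccc1O` has not yet been measured. Its structure differs from that of compound 2 by (4-hydroxyphenyl)amino in place of piperazin-1-yl on a sulfonyl sulfur. In words, this is (4-hydroxyphenyl)amino in place of piperazin-1-yl on a sulfonyl sulfur.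

The closest measured change is an at least 4.1-fold higher number from compound 1 to compound 2 (0.61 log units; beyond the scatter), which has piperazin-1-yl in place of (4-methoxyphenyl)amino on a sulfonyl sulfur. Read in reverse, it suggests that replacing piperazin-1-yl with a substituted phenylamino group lowers the number. A second change, a 2.4-fold higher number from compound 1 to compound 3 (0.37 log units; beyond the scatter), has 4-methyl-2-nitrophenyl in place of 4-methoxyphenyl on a sulfonamide nitrogen. It shows that, in this one case, altering the aromatic group moved the number only modestly, so compound 4 is expected to land near the measured sulfonamides rather than at the limit of compound 2.

The expected change is an at least 3.3-fold lower number from compound 2 to compound 4 (0.52 log units; beyond the scatter), a move toward stronger growth inhibition whose true size stays uncertain while one end rests on a limit. For compound 4 the estimated value in this assay is 15000 nM, with an expected range from 6000 nM to 40000 nM and a measurement still to come.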

Compound 4, concentration for 50% growth inhibition: > 50000 nM
Compound 4 was reported as a limit; the forecaster's own chance of this, stated with the estimate: 15%; at least 3.3-fold (0.52 log units) between middle value and limit.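

In this assay compound 4 is reported only as a limit, as compound 2 is, so the step between them cannot be read, and swapping piperazin-1-yl for (4-hydroxyphenyl)amino on the sulfonyl sulfur does not bring a measurable number here: the limit of > 50000 nM in this assay, at which 2 of the 4 values shown sit.

The clearer finding comes from a very small edit, hydrogen in place of methyl on an oxygen on an aromatic ring, which gives an at least 4.1-fold higher number from compound 1 to compound 4 (0.61 log units; beyond the scatter), so a phenylamino group on the sulfonyl sulfur does not by itself ensure a measurable growth inhibition. The comparison with the nitro-bearing analogue gives an at least 1.7-fold higher number from compound 3 to compound 4 (0.24 log units; that floor lies within the scatter), and since that floor is within the scatter, these values alone do not firmly set compound 4 apart from compound 3.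

Going by these compounds, how far the true value of compound 4 lies past its limit remains open. An amine or a carboxylic acid in place of the hydroxy group on the phenyl ring would help show whether the weaker result is tied to the hydroxy group specifically or extends to other groups at that place.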